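From an amino thiadiazole to a methyl oxadiazole

The source may hold more compounds than are shown below. What is called first, only, known or untested is meant among the compounds shown, and "the series" means these compounds.

In a functional assay on MCF7 cells (Homo sapiens) for cytotoxicity, read by MTT assay, with a stated time of 72 h (a lower number here means a stronger inhibitor, a higher number a weaker inhibitor), compound 1 `Cc1ccc2oc(CSc3nnc(C)s3)cc(=O)c2c1` reaches only a limit, > 25000 nM. Compound 2 `Cc1ccc2oc(CSc3nnc(N)s3)cc(=O)c2c1` likewise reaches only a limit in this assay, > 25000 nM. Between them lies a step that the two limits leave unreadable from compound 1 to compound 2, so compound 2 stands at the limit of > 25000 nM in this assay, at which 2 of the 2 values shown sit, and nothing more. Compound 3 `Cc1ccc2oc(CSc3nnc(C)o3)cc(=O)c2c1` differs from compound 2 by 5-methyl-1,3,4-oxadiazol-2-yl in place of 5-amino-1,3,4-thiadiazol-2-yl on a sulfur. Among the compounds with values here, no measured step bears on this exchange, and with both known values at the limit no direction can be set in this assay. Compound 3 is therefore expected to stay near the limit, at about 30000 nM, within 8000 nM to 100000 nM. The step this estimate means is a step that the limit leaves unreadable from compound 2 to compound 3, an expectation only.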

Compound 3, half-maximal inhibitory concentration: > 25000 nM
Compound 3 was reported as a limit; the forecaster's own chance of this, stated with the estimate: 80%; the middle value is on the limit's open side.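

Compound 3 also reaches only a limit in this assay, so no step among compound 1, compound 2 and compound 3 can be read: the limit of > 25000 nM in this assay, at which 3 of the 3 values shown sit.

The compounds shown leave open how strong each one really is, and whether either exchange changes that.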